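This account rests on a few compounds, and the source may have more. Where it says the series, first, only, none or still open, it means among the compounds named here.

Series measured in a functional assay on DU-145 cells (Homo sapiens) for inhibition, read by MTT assay, with a stated time of 72 h; a higher number here means a weaker inhibitor, a lower number a stronger inhibitor:

- Compound 1 `O=C1C=C(N2CCN(c3ccc(F)cc3)CC2)C(=O)c2ccccc21`: 11700 nM
- Compound 2 `Cc1ccc(N2CCN(C3=CC(=O)c4ccccc4C3=O)CC2)cc1`: 8200 nM
- Compound 3 `O=C1C=C(N2CCN(c3ccc(F)cc3)CC2)C(=O)c2c(O)cccc21`: 8400 nM

Within the data shown here, compound 3, at 8400 nM, is not separated from the other two compounds: all three values lie within the scatter of one another, so the series so far shows no resolved order.

Next is compound 4 `Cc1ccccc1N1CCN(C2=CC(=O)c3cccc(O)c3C2=O)CC1`, which keeps the hydroxy group of compound 3 and changes the aryl group: 2-methylphenyl in place of 4-fluorophenyl on an amine nitrogen in a ring, with 2-methylphenyl in place of 4-fluorophenyl on an amine nitrogen in a ring.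

Among the measured compounds shown here, two measured steps bear on this. The closest is a 1.4-fold lower number from compound 1 to compound 2 (0.15 log units; within the scatter), where methyl replaces fluoro on an aromatic carbon. For the measured compounds named here, it is only a partial guide, as no measured compound carries 2-methylphenyl. The other is a 1.4-fold lower number from compound 1 to compound 3 (0.14 log units; within the scatter), where hydroxy replaces hydrogen on an aromatic carbon, and this change is already present in compound 3. Both steps stay within the scatter, so neither points to a real shift in this assay, and no step beyond the scatter is expected in either direction.

The estimated change is a 1.1-fold lower number from compound 3 to compound 4 (0.02 log units; within the scatter), which is expected to remain within the scatter. For compound 4 the estimated value is 8000 nM, with an expected range of 3800 nM to 16000 nM.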

Compound 4, half-maximal inhibitory concentration: 2300 nM
For compound 4 the middle estimate is 3.5-fold (0.54 log units) above the measured one, and the stated range ends above it.
By their numbers in this assay, from the lowest: compound 4; then compounds 2, 3 and 1 (each within the scatter of the next).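

In this assay, among these compounds, the replacement of 4-fluorophenyl by 2-methylphenyl on the amine nitrogen in a ring gives a 3.7-fold lower number from compound 3 to compound 4 (0.56 log units; beyond the scatter) and is the only step so far that lies beyond the scatter. The aryl group at this position can therefore shift the number in the presence of the hydroxy group, which the earlier swap of methyl for fluoro, a 1.4-fold lower number from compound 1 to compound 2 (0.15 log units; within the scatter) with no hydroxy group present, did not show. No measurement here bears on why the number falls at this position.

The swap changes both the substituent and where it sits on the phenyl ring, and the compounds shown do not separate these two changes or show whether 2-methylphenyl gives a similar step on the core without the hydroxy group. Going by these compounds, it also remains open how other groups on this phenyl ring, such as methoxy, chloro or an amine, would behave in the same setting.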